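Swapping trifluoromethoxy for trifluoromethyl on a shared core

The compounds below may be only part of what the source reports. "The series", "measured", "known", "first", "only" and "open" are said of these compounds alone.

Four compounds share one core and differ only in a single group on it. Compound 1 is `Cc1nc2cc(OC(F)(F)F)ccc2n1-c1ccc(C(=O)NC2CC2)s1`, compound 2 is `Cc1nc2ccc(OC(F)(F)F)cc2n1-c1ccc(C(=O)NC2CC2)s1`, compound 3 is `Cc1nc2cc(C(F)(F)F)ccc2n1-c1ccc(C(=O)NC2CC2)s1`, and the unmeasured compound 4 is `Cc1nc2ccc(C(F)(F)F)cc2n1-c1ccc(C(=O)NC2CC2)s1`. In an in vitro ADME assay on microsomes from liver (Homo sapiens) for pharmacokinetics, read by LC-MS (on this read-out lower numbers stand for slow clearance and higher numbers for fast clearance), compound 1 gives 7 mL/min/kg, compound 2 gives 10 mL/min/kg, and compound 3 gives 4 mL/min/kg. Compound 1 and compound 2 carry the same atoms joined differently; the difference between the two cores is not broken down here.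

From compound 1 to compound 3 the change is trifluoromethyl in place of trifluoromethoxy on an aromatic carbon, and this assay shows a 1.8-fold lower number from compound 1 to compound 3 (0.24 log units; within the scatter). From compound 2 to compound 4 the change is trifluoromethyl in place of trifluoromethoxy on an aromatic carbon, the same change made on the core of compound 2.

Because the measured step was a 1.8-fold lower number from compound 1 to compound 3 (0.24 log units; within the scatter), compound 4 is expected to follow compound 2 with a step of about a 1.7-fold lower number from compound 2 to compound 4 (0.22 log units; within the scatter) in this assay, resting on that single earlier pair alone. Compound 4 is therefore estimated at 6 mL/min/kg, most likely between 3 mL/min/kg and 12 mL/min/kg.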

Compound 4, clearance: 8 mL/min/kg
Compound 4: middle estimate off by 1.3-fold (0.12 log units), on the low side; low and high end bracket the measured number.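

In this assay, putting trifluoromethyl in place of trifluoromethoxy on the core of compound 2 gives a 1.3-fold lower number from compound 2 to compound 4 (0.10 log units; within the scatter), so this step is small enough to be lost among repeated measurements. Set beside the earlier step, it shows that the change behaves alike on both cores as far as this measurement can tell: the same change on two cores in this assay, a 1.8-fold lower number (0.24 log units; within the scatter) from compound 1 to compound 3 and a 1.3-fold lower number (0.10 log units; within the scatter) from compound 2 to compound 4, 1.4-fold (0.15 log units) apart, within the scatter of two such steps. This does not show that the swap itself alters clearance, since neither step stands clear of the scatter, and two cores that differ only in where one group sits say little about a core that differs more widely.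

The compounds shown leave open whether a different group in that place, such as a nitrile, an amine or a carboxylic acid, would give a step beyond the scatter. They also leave open whether the agreement between the two steps would hold on a core with a different amide.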